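This account rests on a few compounds, and the source may have more. Where it says the series, first, only, none or still open, it means among the compounds named here.

Measured so far in a functional assay on MDA-N cells (Homo sapiens) for antiproliferative activity; on this read-out lower numbers stand for stronger inhibition of growth and higher numbers for weaker inhibition of growth:
compound 1 `Cc1ccc2c(O)cc(-c3cccc(Cl)c3)nc2n1`: > 100000 nM (a limit)
compound 2 `Cc1cccc(-c2cc(O)c3ccc(C)nc3n2)c1`: 31.6 nM
compound 3 `Cc1ccnc2nc(-c3cccc4ccccc34)cc(O)c12`: < 10 nM (a limit)

Among the measured compounds shown here, compound 2 holds the only true number of the three, as the other two readings are limits. The next compound to be read is compound 4 `Cc1cccc(-c2cc(O)c3c(C)cc(C)nc3n2)c1`, which differs from compound 2 in one place: methyl in place of hydrogen on an aromatic carbon. This is a methyl in place of hydrogen on an aromatic carbon, opposite the ring nitrogen.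

For the measured compounds named here, the one measured step, an at least 3100-fold lower number from compound 1 to compound 2 (3.50 log units; beyond the scatter), is large, but it is a methyl in place of chloro elsewhere in the molecule, so it gives no direct size for this change. Closer in place is compound 3, which also carries a methyl opposite the ring nitrogen but differs from the others in further ways. The limit for compound 3 is < 10 nM, so a methyl at that place occurs with strong inhibition of growth in this one case.

On that basis no step beyond the scatter is expected in this assay, and the estimated 1.1-fold lower number from compound 2 to compound 4 (0.02 log units; within the scatter) is small, with its direction open. For compound 4 the expected value is 30 nM, estimated to fall between 10 nM and 250 nM.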

Compound 4, concentration for 50% growth inhibition: 20900 nM
Compound 4: middle estimate off by 700-fold (2.84 log units), on the low side, and the stated range ends below it.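

In this assay, among the compounds shown here, the aromatic carbon opposite the ring nitrogen, ortho to a fused ring and meta to a methyl group, proves highly sensitive to a single added methyl, which gives weaker inhibition of growth: a 660-fold higher number from compound 2 to compound 4 (2.82 log units; beyond the scatter); this is the first step read at this position, as the earlier step concerned methyl in place of chloro elsewhere in the molecule. For the compounds shown here, compound 3 also carries a methyl opposite the ring nitrogen, but its reading of < 10 nM is a limit and it differs from compound 4 in more than one place, so no step between them can be read, and a methyl at this position cannot be said to weaken inhibition of growth in every compound of the series. No measurement shown accounts for the size of this step.

Still open, from the compounds shown here alone, is whether the loss of inhibition of growth follows any group at this position or is particular to methyl, since an amine, a methoxy group, a fluoro group or a longer chain there would each test this. Going by these compounds alone, also open is whether the same change gives a step of similar size on a core that keeps a different aromatic group from the one in compound 2.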